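Dropping the Cyano Group: From Compound 2 to Compound 3

A few compounds are considered here, and "the series" means these few. Any claim that something is new, unique, unknown or untested is made for them only; others in the source may bear on it.

Measured so far in a functional assay on MCF7 cells (Homo sapiens) for inhibition, read by MTT assay, with a stated time of 24 h, tested at 10 uM; on this read-out lower numbers stand for less inhibition of growth and higher numbers for more inhibition of growth at the one concentration tested:
- compound 1, `CS(=O)(=O)c1ccc(-c2cnc3[nH]cc(-c4nnc(-c5ccc(Cl)cc5)o4)c(=O)c3c2)cc1`, gives 13.1%
- compound 2, `N#Cc1ccc(-c2cnc3[nH]cc(-c4nnc(-c5ccc(Cl)cc5)o4)c(=O)c3c2)cc1`, gives 19.7%

Within the data shown here, compound 2 holds the higher of the two numbers recorded in this assay, but the single step that reaches it, a number 6.6 percentage points higher from compound 1 to compound 2 (within the scatter), is within the scatter, so the two compounds cannot be told apart on this read-out.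

Compound 3, `O=c1c(-c2nnc(-c3ccc(Cl)cc3)o2)c[nH]c2ncc(-c3ccccc3)cc12`, is the next compound to be measured. Among the measured compounds shown here, its only change from compound 2 is hydrogen in place of cyano on an aromatic carbon. For the measured compounds named here, the one step available, a number 6.6 percentage points higher from compound 1 to compound 2 (within the scatter), concerns the same aromatic carbon and swapped one group for another without a shift beyond the scatter. Going by the values given here, no measured step shows what happens when that carbon carries only hydrogen, so the expectation rests on that single comparison alone.

Because the swap in a number 6.6 percentage points higher from compound 1 to compound 2 (within the scatter) left the number essentially unchanged, compound 3 is expected to stay close to compound 2, with a step of about a number 3.7 percentage points lower from compound 2 to compound 3 (within the scatter) that is not beyond the scatter.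

The estimate for compound 3 in this assay is 16%, with a range from 4% to 30%.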

Compound 3, percent growth inhibition at one concentration: 26.9%
Compound 3: the middle estimate sits 10.9 percentage points below what was measured; the measured number falls inside the stated range.
By their numbers in this assay, from the lowest: compounds 1, 2 and 3 (each within the scatter of the next, the first and the last beyond it).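

In this assay, this carbon now shows its first step beyond the scatter: a number 13.8 percentage points higher from compound 1 to compound 3 (beyond the scatter), a modest gain with hydrogen in place of methylsulfonyl. Taking the nitrile away gives a number 7.2 percentage points higher from compound 2 to compound 3 (within the scatter), so the phenyl of compound 3 and the 4-cyanophenyl of compound 2 cannot be told apart on this read-out, just as compound 1 and compound 2 could not. The three compounds therefore show that this carbon needs no added group to keep the growth inhibition seen at the one tested concentration, and that only the two ends of the series, methylsulfonyl and hydrogen, can be separated, while no evidence is available to explain that separation.

The compounds shown leave open whether an amine, a carboxylic acid or a methoxy group on this same carbon would give a number closer to that of compound 1 or to that of compound 3. They also leave open whether the gap between methylsulfonyl and hydrogen would hold at other concentrations, or on a different core.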